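A few compounds are considered here, and "the series" means these few. Any claim that something is new, unique, unknown or untested is made for them only; others in the source may bear on it.

Among the measured compounds shown here, compound 2 `O=C1NC2(CC2c2ccc3cccc(OCc4ccccc4)c3n2)C(=O)N1C1CCCCC1` is one of two compounds so far tested in a functional assay on the whole organism (strain Kunming) with Mus musculus as the target, with a stated time of 0.5 h (a higher number here means that more compound is needed for the effect, a lower number that less compound is needed), where compound 2 gives 300 mg/kg. Compound 1 `O=C1NC2(CC2c2ccc3cccc(OCc4ccccc4)c3n2)C(=O)N1c1cc(Cl)cc(Cl)c1` gives 300 mg/kg in this assay, and the step of no change at the digits printed from compound 1 to compound 2 (within the scatter) shows that replacing the group on this ring nitrogen left the dose unchanged. Compound 3 `CCC(CO)N1C(=O)NC2(CC2c2ccc3cccc(OCc4ccccc4)c3n2)C1=O` carries the change (1-(hydroxymethyl)propyl in place of cyclohexyl on an amide-type nitrogen in a ring). For the measured compounds named here, only that one measured step bears on this change, and it was flat, so the step of no change at the digits printed from compound 2 to compound 3 (within the scatter) is expected to stay within the scatter. Compound 3 is therefore estimated at 300 mg/kg, with a likely range from 150 mg/kg to 600 mg/kg.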

Compound 3, minimum effective dose: 100 mg/kg
The estimate for compound 3 lay 3.0-fold (0.48 log units) above the measured number, and the stated range ends above it.
By their numbers in this assay, from the lowest: compound 3; then compounds 1 and 2 (each within the scatter of the next).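

This ring nitrogen does respond to its group: in this assay, 1-(hydroxymethyl)propyl gives a 3.0-fold lower number from compound 2 to compound 3 (0.48 log units; beyond the scatter) and a 3.0-fold lower number from compound 1 to compound 3 (0.48 log units; beyond the scatter), although the two ring-bearing groups, cyclohexyl and 3,5-dichlorophenyl, had stood level. Among these three compounds, it is the only group with no ring and the only one with a hydrogen-bond donor and acceptor. Nothing measured here explains the lower number. The hydroxyl and the loss of the ring arrive together, and the compounds shown do not tell which goes with the lower number. A plain butyl chain carrying no oxygen would tell them apart.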